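A few compounds are considered here, and "the series" means these few. Any claim that something is new, unique, unknown or untested is made for them only; others in the source may bear on it.

Series notes. Compound 3 `COc1ccc2nc(C)cc(OC(C)C(=O)Nc3cc(C)cc(C)c3)c2c1` stands second highest of the three numbers in a physicochemical assay for lipophilicity, read by HPLC, in phosphate buffer, measured as chromatographic lipophilicity, at pH 7.4 (a lower number here means a more polar compound, a higher number a more lipophilic compound), with 5.76. Its nearest neighbour is compound 1 `COc1ccc2nc(C)cc(OCC(=O)Nc3cc(C)cc(C)c3)c2c1`, which in this assay gives 5.64; the step of a number 0.12 log units higher from compound 1 to compound 3 (within the scatter) lies within the scatter. Furthest off is compound 2 `Cc1cc(C)cc(NC(=O)COc2cc(C)nc3ccc(OC(F)(F)F)cc23)c1`, which in this assay gives 6.79; the step of a number 1.15 log units higher from compound 1 to compound 2 (beyond the scatter) lies beyond the scatter.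

Compound 4 `COc1ccc2nc(C)cc(OC(C)(C)C(=O)Nc3cc(C)cc(C)c3)c2c1` has not yet been run in this assay. It differs from compound 3 by methyl in place of hydrogen on a saturated chain carbon bound to a carbonyl carbon, an oxygen on an aromatic ring and a saturated chain carbon. Of the measured steps, a number 0.12 log units higher from compound 1 to compound 3 (within the scatter) is the one that bears on this change: that step also placed a methyl on the same saturated chain carbon, and it was small, within the scatter. The change from compound 1 to compound 2 concerns the group on the oxygen on an aromatic ring and does not touch the chain, so it gives no guidance here. A further methyl on the chain carbon is therefore expected to move this assay little, if at all, with the same upward tendency as the first. The estimated step is a number 0.19 log units higher from compound 3 to compound 4 (within the scatter). For compound 4 the expected value in this assay is 5.95, with a range from 5.65 to 6.3.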

Compound 4, distribution coefficient: 6.37
Estimate against measurement, compound 4: 0.42 log units below; the measured number lies above the stated range.
By their numbers in this assay, from the lowest: compounds 1 and 3 (each within the scatter of the next); then compound 4; then compound 2.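

In this assay, the second methyl on the saturated chain carbon gives a number 0.61 log units higher from compound 3 to compound 4 (beyond the scatter), whereas the first methyl on that same carbon gave a number 0.12 log units higher from compound 1 to compound 3 (within the scatter). Among these compounds, the same replacement of hydrogen by methyl at this position therefore does not behave as a fixed increment in this pair of steps: only the step that places a second methyl on the carbon lies beyond the scatter, and compound 4 now stands clear of compound 3 in this assay. Nothing available here accounts for the difference between the two steps.

The compounds shown carry only hydrogen and methyl on this chain carbon, so it remains open whether an ethyl group, a cyclopropane ring built on that carbon, or a hydroxyl or amine group there would extend the same trend or break it. From the compounds shown here alone, it also remains open whether the step seen on replacing methyl with trifluoromethyl on the oxygen on the aromatic ring, a number 1.15 log units higher from compound 1 to compound 2 (beyond the scatter), would carry over unchanged to a compound with two methyls on the chain carbon.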